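Two arrangements of three methoxy groups on a shared core

The compounds below may be only part of what the source reports. "The series", "measured", "known", "first", "only" and "open" are said of these compounds alone.

Of the compounds shown here, two have been measured, and they differ from each other in more than one place. Compound 1 `COc1cc(OC)c(-c2nc3cc(/C=C4\SC(=O)NC4=O)ccc3[nH]2)cc1OC` and compound 2 `COc1cc(-c2nc3cc(/C=C4\SC(=O)N(Cc5cccc(C)c5)C4=O)ccc3[nH]2)cc(OC)c1OC` share a fused two-ring core carrying a phenyl ring that bears three methoxy groups. In a functional assay on HT-1080 cells (Homo sapiens) for inhibition, read by MTT assay, with a stated time of 48 h (a higher number here means a weaker inhibitor, a lower number a stronger inhibitor), compound 2 gives 4580 nM, while compound 1 gives 6350 nM in this assay; the two numbers lie within the usual scatter of each other, so nothing can be read into their order.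

Compound 3 `COc1cc(OC)c(-c2nc3cc(/C=C4\SC(=O)N(Cc5cccc(C)c5)C4=O)ccc3[nH]2)cc1OC` has not yet been measured. It keeps everything in compound 2 except the pattern of the three methoxy groups: 2,4,5-trimethoxyphenyl in place of 3,4,5-trimethoxyphenyl on an aromatic carbon. Going by the values given here, no pair of measured compounds differing in exactly this way is available, so the size of this move on its own is not known; the only guide is that compound 1, which carries the same 2,4,5-trimethoxyphenyl group, sits within the scatter of compound 2.

The step from compound 2 to compound 3 is therefore expected to be small, a 1.1-fold higher number from compound 2 to compound 3 (0.04 log units; within the scatter), with no clear direction. Compound 3 is estimated at 5000 nM in this assay, within a range from 2000 nM to 15000 nM.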

Compound 3, half-maximal inhibitory concentration: 190 nM
Estimate against measurement, compound 3: 26-fold (1.42 log units) above; measured number outside the range, below it.
By their numbers in this assay, from the lowest: compound 3; then compounds 2 and 1 (each within the scatter of the next).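

In this assay the pattern of the three methoxy groups on the phenyl ring, which sits on an aromatic carbon between two ring nitrogen atoms, turns out to matter a great deal: rearranging the same atoms from 3,4,5-trimethoxyphenyl to 2,4,5-trimethoxyphenyl gives a 24-fold lower number from compound 2 to compound 3 (1.38 log units; beyond the scatter) with nothing added or lost. The 3-methylbenzyl group on the amide-type nitrogen in a ring counts just as clearly when the 2,4,5-trimethoxyphenyl group is present, since putting it in place of hydrogen gives a 33-fold lower number from compound 1 to compound 3 (1.52 log units; beyond the scatter) in the same assay. Among these compounds the low number appears only in compound 3, which carries both groups, and nothing shown gives a measured reason for it.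

Whether the methoxy pattern has any such effect on a compound with hydrogen on that nitrogen stays open, as both steps shown end at compound 3. Also open, going by these compounds, is what other groups on that nitrogen would do, such as a plain benzyl, a longer phenylethyl chain or a chain ending in a carboxylic acid.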